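From 4-methoxyphenyl to anilino on the shared core

The compounds below may be only part of what the source reports. "The series", "measured", "known", "first", "only" and "open" are said of these compounds alone.

In a functional assay on K562 cells (Homo sapiens) for antiproliferative activity, read by MTT assay, with a stated time of 72 h (on this read-out higher numbers stand for weaker inhibition and lower numbers for stronger inhibition), compound 1 `COc1cc(C(=O)c2sc3ccccc3c2-c2ccccc2)cc(OC)c1OC` gives 2100 nM and compound 2 `COc1ccc(-c2c(C(=O)c3cc(OC)c(OC)c(OC)c3)sc3ccccc23)cc1` gives 1700 nM, so the two stand level, with a 1.2-fold lower number from compound 1 to compound 2 (0.09 log units; within the scatter). Compound 3 `COc1ccc(-c2c(C(=O)c3cc(OC)c(OC)c(OC)c3)sc3ccccc23)cc1C` reads > 10000 nM, which is a limit of the assay. Compound 4 `COc1cc(C(=O)c2sc3ccccc3c2Nc2ccccc2)cc(OC)c1OC` has anilino in place of 4-methoxyphenyl on an aromatic carbon. Among the compounds with values here, two measured steps bear on this place, and both alter only the outer ring: a 1.2-fold lower number from compound 1 to compound 2 (0.09 log units; within the scatter), and an at least 5.8-fold higher number from compound 2 to compound 3 (0.76 log units; beyond the scatter). Within the data shown here, no measured compound has the anilino group. With compound 1 and compound 2 level, no shift beyond the scatter is expected in this assay, though with low confidence. The expected change is a 1.2-fold higher number from compound 2 to compound 4 (0.07 log units; within the scatter). Compound 4 is estimated at 2000 nM, within an expected range of 300 nM to 10000 nM.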

Compound 4, half-maximal inhibitory concentration: 2300 nM
Estimate against measurement, compound 4: 1.2-fold (0.06 log units) below, within the range that was stated.
By their numbers in this assay, from the lowest: compounds 2, 1 and 4 (each within the scatter of the next). At a limit, above all of these: compound 3.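

The anilino group, which carries a hydrogen-bond donor that 4-methoxyphenyl lacks, leaves the number in this assay level with both earlier ring-bearing compounds: a 1.4-fold higher number from compound 2 to compound 4 (0.13 log units; within the scatter), and a 1.1-fold higher number from compound 1 to compound 4 (0.04 log units; within the scatter). Compound 3 stands at a limit of the assay: the limit of > 10000 nM in this assay, at which 1 of the 4 values shown sits. The step to the anilino group reads an at least 4.3-fold lower number from compound 3 to compound 4 (0.63 log units; beyond the scatter), so compound 4 does not share the loss seen with 4-methoxy-3-methylphenyl. Open, going by these compounds, is how a methoxy or methyl group on the anilino ring would read, and whether a morpholine in place of anilino would stay level.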